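A Piperazine Group Returns in Place of Methoxy

The source may report more compounds than this note shows. Statements on the series, on what has been measured and on what is new or still open speak of the compounds shown alone.

In a functional assay on Raji cells (Homo sapiens) for antiproliferative activity, read by CCK-8 assay, with a stated time of 48 h (on this read-out lower numbers stand for stronger inhibition and higher numbers for weaker inhibition), compound 1 `C=CC(=O)Nc1cccc(-n2cnc3cnc(Nc4ccc(N5CCN(C)CC5)cc4)nc32)c1` gives 7550 nM. Compound 2 `C=CC(=O)Nc1cccc(-n2cnc3cnc(Nc4ccc(OC)cc4)nc32)c1` gives 31200 nM, the higher of the two numbers and so the weaker inhibition of this pair. Compound 3 `C=CC(=O)Nc1cccc(-n2cnc3cnc(Nc4ccc(N5CCN(S(C)(=O)=O)C(C)C5)cc4)nc32)c1` has not yet been measured. It carries 3-methyl-4-(methylsulfonyl)piperazin-1-yl in place of methoxy on an aromatic carbon. Among the compounds with values here, only one measured step bears on this change: a 4.1-fold higher number from compound 1 to compound 2 (0.62 log units; beyond the scatter), where methoxy replaced 4-methylpiperazin-1-yl. The entering group is also built on a six-membered non-aromatic ring, so part of that step may be expected to reverse in this assay. Within the data shown here, no measured compound shows what the methylsulfonyl group or the extra methyl does, so the expectation stays loose. The expected step is a 2.8-fold lower number from compound 2 to compound 3 (0.45 log units; beyond the scatter), towards stronger inhibition. The estimated value for compound 3 is 11000 nM, with a range of 3500 nM to 32000 nM.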

Compound 3, half-maximal inhibitory concentration: 31700 nM
Beside the measured number, compound 3's estimate is 2.9-fold (0.46 log units) below it, and the stated range covers the measured number.
By their numbers in this assay, from the lowest: compound 1; then compounds 2 and 3 (each within the scatter of the next).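

In this assay a piperazine ring at this position does not by itself bring back the number of compound 1. The step of a 1.0-fold higher number from compound 2 to compound 3 (0.01 log units; within the scatter) leaves 3-methyl-4-(methylsulfonyl)piperazin-1-yl and methoxy indistinguishable here, despite the larger heavy-atom count of the entering group. What is attached to the piperazine ring therefore counts, as the step of a 4.2-fold higher number from compound 1 to compound 3 (0.62 log units; beyond the scatter) separates two groups built on that ring, and no evidence at hand explains either step.

The compounds shown leave open whether the methylsulfonyl group, the extra ring methyl or both account for this gap, as neither appears without the other. A plain piperazin-1-yl group, 4-methylsulfonylpiperazin-1-yl without the ring methyl, or 3,4-dimethylpiperazin-1-yl could each help to separate these two parts.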